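The compounds below may be only part of what the source reports. "The series", "measured", "known", "first", "only" and "open" are said of these compounds alone.

Working notes on the chalcone-type series carrying a shared core.

Three compounds have numbers in a functional assay on Malme-3M cells (Homo sapiens) for inhibition, read by sulforhodamine B assay, with a stated time of 48 h; a higher number here means a weaker inhibitor of growth, a lower number a stronger inhibitor of growth. Compound 1 `COc1cc(-c2cc(/C=C/C(=O)c3ccc(N)cc3)[nH]n2)cc(OC)c1OC` gives 2050 nM. Compound 2 `COc1ccc(-c2cc(/C=C/C(=O)c3ccc(OC)c(OC)c3)[nH]n2)cc1` gives 1620 nM, which is within the scatter of the number for compound 1; the two differ in more than one place, so nothing beyond what the two values show can be said of them. For the measured compounds named here, compound 3 `COc1cc(-c2cc(/C=C/C(=O)c3ccc(Cl)c(Cl)c3)[nH]n2)cc(OC)c1OC` gives 29200 nM, and the one single-point step on record, a 14-fold higher number from compound 1 to compound 3 (1.15 log units; beyond the scatter), is the only large move in the set. Compound 1 therefore stands second highest of the three numbers, close to compound 2 and far below compound 3.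

Compound 4 `COc1ccc(-c2cc(/C=C/C(=O)c3ccc(N)cc3)[nH]n2)cc1OC` is not yet measured. Its difference from compound 1 is hydrogen in place of methoxy on an aromatic carbon. Going by the values given here, no measured step bears directly on this change: the one recorded step concerns the group on the carbonyl carbon, not the methoxy groups on the other ring. The closest hint is that compound 2, with a single methoxy on that ring and other changes elsewhere, sits within the scatter of compound 1. The step in this assay is therefore expected to be small, a 1.2-fold higher number from compound 1 to compound 4 (0.09 log units; within the scatter), with no direction beyond the scatter asserted. Compound 4 is estimated at 2500 nM, with a range from 900 nM to 7000 nM.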

Compound 4, concentration for 50% growth inhibition: 6720 nM
Compound 4: the middle estimate sits 2.7-fold (0.43 log units) below what was measured; the range from low to high includes it.
By their numbers in this assay, from the lowest: compounds 2 and 1 (each within the scatter of the next); then compound 4; then compound 3.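

In this assay the change gives a 3.3-fold higher number from compound 1 to compound 4 (0.52 log units; beyond the scatter), so the methoxy on this aromatic carbon, ortho to a methoxy group and meta to a large group, cannot be replaced by hydrogen without a loss of growth inhibition beyond the scatter. For the compounds shown here, until now the only single-place step concerned the carbonyl side, a 14-fold higher number from compound 1 to compound 3 (1.15 log units; beyond the scatter); the methoxy-bearing ring now has a step of its own, modest beside that large one. No measured evidence at hand explains the loss at this position.

On these data alone, it remains open whether this carbon needs a methoxy as such or would accept another small group: a fluorine, a methyl or a hydroxyl in the same place would help separate these cases, and an ethoxy would show how a longer chain fares there. Also open, as far as these compounds go, is whether the same hydrogen-for-methoxy step holds in size with 3,4-dichlorophenyl on the carbonyl carbon, that is, starting from compound 3 rather than from compound 1.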